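This account rests on a few compounds, and the source may have more. Where it says the series, first, only, none or still open, it means among the compounds named here.

Working notes on a small cinnamoyl series examined in an ADME assay on L929 cells (Mus musculus) for cytotoxicity, read by resazurin assay, with a stated time of 72 h; on this read-out higher numbers stand for weaker inhibition and lower numbers for stronger inhibition. Compound 1 `O=C(/C=C/c1ccc2c(c1)B(O)OC2)c1ccc(O)cc1` is the reference point. In this assay compound 1 gives only a limit, > 10 ug/mL, so its place on the scale is not fixed; it stands at the limit of > 10 ug/mL in this assay, at which 1 of the 2 values shown sits, and cannot be ranked against a numbered value. Compound 2 `OB1OCc2ccc(/C=C/C(O)c3ccccc3)cc21` is the other measured member; in this assay compound 2 gives 2.88 ug/mL. Between these two there is a limit beside a number and nothing more is computed.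

Compound 3 `O=C(/C=C/c1ccc2c(c1)B(O)OC2)c1cccc(O)c1` is the next member awaiting measurement. The change from compound 1 to compound 3 is 3-hydroxyphenyl in place of 4-hydroxyphenyl on a carbonyl carbon. For the measured compounds named here, no measured step bears on exchanging 4-hydroxyphenyl for 3-hydroxyphenyl on a carbonyl carbon, so the expectation rests on compound 1 alone. The expected step is a step that the limit leaves unreadable from compound 1 to compound 3, nothing beyond the usual scatter, and the chance that compound 3 also returns only a limit is judged high. Compound 3 is estimated at 12 ug/mL in this assay, with a range from 5 ug/mL to 30 ug/mL.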

Compound 3, half-maximal inhibitory concentration: 7.56 ug/mL
Compound 3: middle estimate off by 1.6-fold (0.20 log units), on the high side; the measured number falls inside the stated range.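

In this assay, 3-hydroxyphenyl in place of 4-hydroxyphenyl on a carbonyl carbon gives the series its first readable step, an at least 1.3-fold lower number from compound 1 to compound 3 (0.12 log units; that floor lies within the scatter). This position can therefore return a numbered value with the rest of compound 1 unchanged, but only the floor of the step is known, and since that floor lies within the scatter, the exchange is not yet shown to matter. The true size of the step stays unknown because compound 1 gives only a limit: the limit of > 10 ug/mL in this assay, at which 1 of the 3 values shown sits.

The compounds shown leave open how a plain phenyl, a 3-methoxyphenyl or a 3-aminophenyl would read on this carbonyl carbon, so the part played by the hydroxyl itself cannot be separated from that of the aromatic ring carrying it. They also leave open whether any real difference exists between 4-hydroxyphenyl and 3-hydroxyphenyl here, which would take a numbered value for compound 1 on the same read-out.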